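Removing the arylsulfonyl group from a cytotoxic oxindole

The source may hold more compounds than are shown below. What is called first, only, known or untested is meant among the compounds shown, and "the series" means these compounds.

Measured compounds:
compound 1, `CS(=O)(=O)Nc1ccc2c(c1)/C(=C(/Nc1ccc(CN3CCCCC3)cc1)c1ccccc1)C(=O)N2`, 0.2 uM
compound 2, `O=C1Nc2ccc(NS(=O)(=O)c3ccccc3)cc2/C1=C(/Nc1ccc(CN2CCCCC2)cc1)c1ccccc1`, 3.29 uM

Compound 1 and compound 2 share one core and differ only at the sulfonyl sulfur attached to the ring nitrogen. In an ADME assay on HepG2 cells (Homo sapiens) for cytotoxicity, read by MTT assay, with a stated time of 48 h (on this read-out lower numbers stand for higher toxicity in this test and higher numbers for lower toxicity in this test), compound 1 gives 0.2 uM, and compound 2 gives 3.29 uM, which is the higher of the two numbers. That single step, a 16-fold higher number from compound 1 to compound 2 (1.22 log units; beyond the scatter), is the only one available, and it shows that what sits on the sulfonyl sulfur changes the read-out strongly.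

Compound 3, `Nc1ccc2c(c1)/C(=C(/Nc1ccc(CN3CCCCC3)cc1)c1ccccc1)C(=O)N2`, has not been measured. It differs from compound 2 by hydrogen in place of phenylsulfonyl on a nitrogen on an aromatic ring, so the whole phenylsulfonyl group leaves and a plain amino group remains. For the measured compounds named here, no measured step removes the sulfonyl group outright, so the direction is uncertain; the one step at this position was large, and a change of similar size in either direction seems possible. Compound 3 is therefore expected to land between the two measured values, with a step of a 3.3-fold lower number from compound 2 to compound 3 (0.52 log units; beyond the scatter), and an estimate of 1 uM, within a range from 0.2 uM to 5 uM.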

Compound 3, half-maximal toxic concentration: > 6 uM
Compound 3: only a limit was reported (the forecaster's own chance of this, stated with the estimate: 5%); middle value at least 6.0-fold (0.77 log units) away from the limit.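

In this assay compound 3 gives > 6 uM, which is a limit of the assay and not a number. Taking the sulfonyl group off altogether leaves a plain amino group and gives an at least 30-fold higher number from compound 1 to compound 3 (1.47 log units; beyond the scatter), so the low number of compound 1 belongs to the methylsulfonyl compound and does not persist once that group is gone, and a sulfonyl group on this nitrogen is not needed for a high number on this read-out. Against the phenylsulfonyl compound the picture is less firm, with an at least 1.8-fold higher number from compound 2 to compound 3 (0.26 log units; that floor lies within the scatter), so the two cannot be firmly ordered, and the reading for compound 3 stops at a ceiling: the limit of > 6 uM in this assay, at which 1 of the 3 values shown sits.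

The compounds shown leave open how far the number of compound 3 really lies from that of compound 2, and whether the low number is peculiar to methyl on the sulfonyl sulfur or would also appear with ethyl or a longer chain there. They also leave open what an acetyl group on the same nitrogen, which puts a carbonyl in place of the sulfonyl, would do.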